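Replacing Thiophene with Phenyl on a Weak Cytotoxic Pyridine

This account rests on a few compounds, and the source may have more. Where it says the series, first, only, none or still open, it means among the compounds named here.

Measured compounds:
- compound 2, `Oc1ccc(-c2cc(-c3ccsc3)nc(-c3cccc(Cl)c3)c2)cc1`, 7390 nM
- compound 1, `Oc1ccc(-c2cc(-c3ccncc3)nc(-c3cccc(Cl)c3)c2)cc1`, "not determined" (no result reported)

Within the data shown here, in a functional assay on T47D cells (Homo sapiens) for cytotoxicity, read by CCK-8 assay and cell counting, with a stated time of 2 days (a lower number here means a stronger inhibitor, a higher number a weaker inhibitor), compound 2 gives 7390 nM, which is the only number available; compound 1 was tested in this assay without a reported result, so compound 2 stands alone and cannot be ranked against anything.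

Compound 3, `Oc1ccc(-c2cc(-c3ccccc3)nc(-c3cccc(Cl)c3)c2)cc1`, differs from compound 2 in one place: phenyl in place of thiophen-3-yl on an aromatic carbon. The rest of the shared core, including the 3-chlorophenyl group and the 4-hydroxyphenyl group, stays the same. Among the measured compounds shown here, no measured pair in this set shows how such an exchange shifts the readout, so the expectation rests on the single value of compound 2 alone. A step of about the same size as the usual scatter, in either direction, is expected, rather than a clear change.

Compound 3 is therefore estimated at 7000 nM, with a range from 2500 nM to 20000 nM in this assay.

The expected step from compound 2 to compound 3 is a 1.1-fold lower number from compound 2 to compound 3 (0.02 log units; within the scatter), essentially none beyond the scatter.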

Compound 3, half-maximal inhibitory concentration: 4790 nM
For compound 3 the middle estimate is 1.5-fold (0.16 log units) above the measured one; low and high end bracket the measured number.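

Exchanging thiophen-3-yl for phenyl next to the ring nitrogen gives a 1.5-fold lower number from compound 2 to compound 3 (0.19 log units; within the scatter) in this assay. At this position, then, a five-membered aromatic ring with sulfur and a six-membered aromatic ring of carbon only cannot be told apart by this read-out, and the sulfur atom is not needed to retain the activity of compound 2. No measured property of these groups is available to bear on this result.

From the compounds shown here alone, what an amine, a carboxylic acid or a longer chain would do at this position stays open, as does whether any group placed here can move the number beyond the scatter. Compound 1 offers no further comparison, since its entry in this assay reads "not determined" (no result reported).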